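This account rests on a few compounds, and the source may have more. Where it says the series, first, only, none or still open, it means among the compounds named here.

Measured so far:
- compound 1, `CC(O)C1=CC(=O)c2ccccc2C1=O`: 6400 nM
- compound 2, `O=C(C1=CC(=O)c2ccccc2C1=O)c1ccc(Cl)cc1`: 72900 nM
- compound 3, `Cc1cc(Cl)ccc1C(=O)C1=CC(=O)c2ccccc2C1=O`: 50400 nM

In a functional assay on WHCO1 cells (Homo sapiens) for cytotoxicity, read by MTT assay, with a stated time of 24 h (on this read-out higher numbers stand for weaker inhibition and lower numbers for stronger inhibition), compound 1 stands lowest of the three numbers; the nearest, compound 3, lies beyond the scatter above it, and compound 2 further still. Compound 4, `O=C1C=C(C(O)c2ccc(F)cc2)C(=O)c2ccccc21`, differs from compound 1 in one place: 4-fluorophenyl in place of methyl on a saturated chain carbon bound to a double-bonded ring carbon and an oxygen on a saturated carbon. Among the compounds with values here, only one measured step exists, a 1.4-fold lower number from compound 2 to compound 3 (0.16 log units; within the scatter), and it concerns a methyl on an aromatic carbon of a different side group, so it does not bear directly on this change. Compounds 2 and 3, which carry an aryl group joined through a carbonyl, give much higher numbers than compound 1 with its hydroxyethyl group; compound 4 keeps the oxygen on the saturated carbon but brings in the aryl ring, so a moderate rise in the number is expected rather than a large one, though the uncertainty is wide. Compound 4 is therefore estimated at 13000 nM, with a range from 4000 nM to 45000 nM, meaning an expected step of a 2.0-fold higher number from compound 1 to compound 4 (0.31 log units; beyond the scatter).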

Compound 4, half-maximal inhibitory concentration: 5100 nM
Compound 4: middle estimate off by 2.5-fold (0.41 log units), on the high side; the range from low to high includes it.
By their numbers in this assay, from the lowest: compounds 4 and 1 (each within the scatter of the next); then compounds 3 and 2 (each within the scatter of the next).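

In this assay, putting 4-fluorophenyl in place of methyl on this saturated chain carbon gives a 1.3-fold lower number from compound 1 to compound 4 (0.10 log units; within the scatter) and so leaves the two compounds indistinguishable on this read-out. Within the data shown here, this is the first measured change at this position, and it shows that a small methyl and a much larger aromatic ring, seven heavy atoms in place of one, can give matching numbers while the hydroxyl-bearing carbon stays in place. No measurement that would explain this match is available.

The compounds shown leave open what the fluorine contributes on its own, which a plain phenyl at this position would help to separate from the ring. They also leave open whether a longer chain or an amine placed here would give a similar number.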